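Swapping the sulfonyl heteroaryl for a dimethylphenyl ring

The source may hold more compounds than are shown below. What is called first, only, known or untested is meant among the compounds shown, and "the series" means these compounds.

Compound 3 `CC1CCN(C2CCN(S(=O)(=O)c3cnc(Cl)s3)CC2)CC1` is one of three compounds tested in an ADME assay on HCT-116 cells (Homo sapiens) for cytotoxicity, read by CellTiter-Glo, with a stated time of 72 h (on this read-out lower numbers stand for stronger inhibition and higher numbers for weaker inhibition), and what is recorded for it is a limit of the assay: in this assay compound 3 gives > 10000 nM. Compound 1 `Cc1noc(C)c1S(=O)(=O)N1CCC(N2CCC(C)CC2)CC1` likewise reaches only a limit, giving > 10000 nM. Compound 2 `CC1CCN(C2CCN(S(=O)(=O)c3cccnc3Cl)CC2)CC1` also sits at a limit, with > 10000 nM. Because (the limit of > 10000 nM in this assay, at which 3 of the 3 values shown sit), none of the steps between them can be read: the change from compound 1 to compound 2 is a step that the two limits leave unreadable from compound 1 to compound 2, from compound 1 to compound 3 it is a step that the two limits leave unreadable from compound 1 to compound 3, and from compound 2 to compound 3 it is a step that the two limits leave unreadable from compound 2 to compound 3. Compound 4 `Cc1ccc(S(=O)(=O)N2CCC(N3CCC(C)CC3)CC2)cc1C` differs from compound 3 in one place: 3,4-dimethylphenyl in place of 2-chloro-1,3-thiazol-5-yl on a sulfonyl sulfur. For the measured compounds named here, no measured step gives a readable size for this change; every earlier exchange on the sulfonyl sulfur left the read-out at the limit. The resulting step is therefore expected to be a step that the limit leaves unreadable from compound 3 to compound 4. Compound 4 is estimated at 15000 nM, within 4000 nM to 60000 nM, and most likely reported again only as a limit.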

Compound 4, half-maximal inhibitory concentration: > 5000 nM
Compound 4 ended at the assay's limit; the forecaster's own chance of this, stated with the estimate: 80%; the middle value is on the limit's open side.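

In this assay compound 4 gives > 5000 nM, which is a limit of the assay. For the compounds shown here, compounds 1, 2 and 3 also stand at limits, and no step from any of them to compound 4 can be read. The compounds shown leave open whether any group on the sulfonyl sulfur gives a measurable value.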